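A few compounds are considered here, and "the series" means these few. Any claim that something is new, unique, unknown or untested is made for them only; others in the source may bear on it.

Measured so far:

Compound 1: `C=CC(=O)N1CC[C@H](N2C(=O)N(c3ccccc3)Cc3cnc(Nc4cccc(N5CCN(C)CC5)c4)nc32)C1` — 3380 nM
Compound 2: `C=CC(=O)N1CC[C@H](N2C(=O)N(c3ccccc3)Cc3cnc(Nc4ccc(N5CCN(C)CC5)cc4)nc32)C1` — 2830 nM

Both compounds were tested in an ADME assay on the whole organism (strain Sprague-Dawley) for pharmacokinetics, with Rattus norvegicus as the target, read by LC-MS, at a dose of 5 mg/kg by the intravenous route; on this read-out higher numbers stand for higher exposure at the dose given and lower numbers for lower exposure. Compound 1 gives 3380 nM, and compound 2 gives 2830 nM. Compound 2 sits at one end of this pair of numbers, but its gap to compound 1 falls within the usual scatter of repeated measurements, so the two exposures cannot be told apart on these data.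

Compound 3 is `C=CC(=O)N1CC[C@H](N2C(=O)N(c3ccccc3)Cc3cnc(Nc4ccccc4)nc32)C1`, not yet measured. Relative to compound 2 the only change is hydrogen in place of 4-methylpiperazin-1-yl on an aromatic carbon; everything else in the shared core stays the same.

Within the data shown here, no step between measured compounds is available for this kind of change, so there is no measured guide to its size. In the absence of such a guide, the expectation for compound 3 in this assay is a number close to that of compound 2, with any shift small and its direction uncertain. The expected step is a 1.2-fold higher number from compound 2 to compound 3 (0.09 log units; within the scatter). On that basis compound 3 is estimated at 3500 nM, with a plausible range from 1400 nM to 9000 nM.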

Compound 3, maximal plasma concentration: 14900 nM
The estimate for compound 3 lay 4.3-fold (0.63 log units) below the measured number; measured number above the stated range.
By their numbers in this assay, from the lowest: compounds 2 and 1 (each within the scatter of the next); then compound 3.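

In this assay hydrogen in place of 4-methylpiperazin-1-yl on an aromatic carbon gives a 5.3-fold higher number from compound 2 to compound 3 (0.72 log units; beyond the scatter) and likewise a 4.4-fold higher number from compound 1 to compound 3 (0.64 log units; beyond the scatter) so the two available comparisons agree in direction and both lie beyond the scatter. The earlier pair, compound 1 and compound 2, carry the group on different carbons of the same ring, and their numbers lie within the scatter of each other, so those two compounds showed no effect of where the group sits; compound 3 now shows that having the group or not having it does matter on this read-out, with compound 3 the highest of the three. Nothing measured here bears on the reason for this rise.

These compounds compare only the whole 4-methylpiperazin-1-yl group with a bare hydrogen, so they leave open which part of the group goes with the lower numbers: its methyl, its ring or its nitrogens. A smaller group on the same carbon, such as a methoxy, a dimethylamino or a morpholine ring, would show whether the number falls only with the full group or with any substituent at all.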